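Acetyl(methyl)amino Variant of a Primary Amine Sulfone

The source may hold more compounds than are shown below. What is called first, only, known or untested is meant among the compounds shown, and "the series" means these compounds.

Two compounds sharing one core have been measured so far:
compound 1, `NC[C@@H]1CCCc2cc(S(=O)(=O)c3cccc(F)c3)ccc21` — 0.0794 nM in an assay on isolated protein for displacement of a labelled ligand from 5-hydroxytryptamine receptor 6 (Homo sapiens); on this read-out lower numbers stand for stronger inhibition and higher numbers for weaker inhibition
compound 2, `N=C(N)NC(=O)C[C@@H]1CCCc2cc(S(=O)(=O)c3cccc(F)c3)ccc21` — 0.631 nM in this assay

Compound 1 stands with the lowest of the two numbers; its nearest neighbour is compound 2, reached through a 7.9-fold higher number from compound 1 to compound 2 (0.90 log units; beyond the scatter), a modest weakening that lies beyond the scatter. Compound 3, `CC(=O)N(C)C[C@@H]1CCCc2cc(S(=O)(=O)c3cccc(F)c3)ccc21`, has not yet been measured. It differs from compound 1 in one place: acetyl(methyl)amino in place of amino on a saturated chain carbon bound to a saturated ring carbon. Among the compounds with values here, the one measured step that bears on this change is a 7.9-fold higher number from compound 1 to compound 2 (0.90 log units; beyond the scatter), where a larger group took the place of the single nitrogen atom on the same saturated chain carbon. Compound 3 also exchanges the amino group at that carbon for a larger group, so the expected direction is the same, towards a higher number in this assay, and the expected size is at least comparable with the measured step, with a wide margin of uncertainty in both directions. For compound 3 the estimated result is 3 nM, with a range from 0.3 nM to 30 nM, which corresponds to an expected step of a 38-fold higher number from compound 1 to compound 3 (1.58 log units; beyond the scatter).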

Compound 3, inhibition constant: 1.59 nM
The estimate for compound 3 lay 1.9-fold (0.28 log units) above the measured number; the measured number falls inside the stated range.
By their numbers in this assay, from the lowest: compound 1; then compound 2; then compound 3.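

In this assay the exchange of amino for acetyl(methyl)amino on a saturated chain carbon bound to a saturated ring carbon brings a 20-fold higher number from compound 1 to compound 3 (1.30 log units; beyond the scatter) and so gives a second, larger step in the same direction at this position, with compound 1 still holding the lowest number of the three. The two larger groups are not equivalent, since going from the group in compound 2 to acetyl(methyl)amino brings a 2.5-fold higher number from compound 2 to compound 3 (0.40 log units; beyond the scatter) even though acetyl(methyl)amino has the smaller heavy-atom count of the two, so heavy-atom count alone does not order these compounds. No measurement at hand explains why the numbers rise at this position or why the two larger groups differ.

Because acetyl and methyl enter together on the nitrogen in compound 3, the compounds shown do not separate the share of each, which a methylamino or an acetylamino group at the same carbon would address. Also open, from the compounds shown here alone, is how a longer chain carrying the primary amine, or a carboxylic acid at this carbon, would read in this assay against the amine of compound 1.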